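From methoxy to trifluoromethyl: a cytotoxicity step

A few compounds are considered here, and "the series" means these few. Any claim that something is new, unique, unknown or untested is made for them only; others in the source may bear on it.

Values so far in a functional assay on V79 cells (Cricetulus griseus) for cytotoxicity, read by colony formation; a higher number here means a weaker inhibitor, a lower number a stronger inhibitor
- Compound 1 `NC1CCN(c2c(F)cc3c(=O)c(C(=O)O)cn(C4CC4)c3c2C(F)(F)F)C1` gives 300 ug/mL; 300 ug/mL; 300 ug/mL (3 entries)
- Compound 2 `NCC1CCN(c2c(F)cc3c(=O)c(C(=O)O)cn(C4CC4)c3c2C(F)(F)F)C1` gives 38 ug/mL
- Compound 3 `COc1c(N2CC(C)NC(C)C2)c(F)cc2c(=O)c(C(=O)O)cn(C3CC3)c12` gives > 500 ug/mL as a limit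

Compound 3 stands at > 500 ug/mL, which is a limit of the assay and not a number. Compound 4 `CC1CN(c2c(F)cc3c(=O)c(C(=O)O)cn(C4CC4)c3c2C(F)(F)F)CC(C)N1`, not yet measured, has trifluoromethyl in place of methoxy on an aromatic carbon. Compound 1 and compound 2 also carry trifluoromethyl, with other amine groups. With compound 1 at 300 ug/mL; 300 ug/mL; 300 ug/mL (3 entries) and compound 2 at 38 ug/mL, a move beyond the scatter toward a lower number, meaning a stronger inhibitor, is expected. The expected change is an at least 4.1-fold lower number from compound 3 to compound 4 (0.61 log units; beyond the scatter). The estimate for compound 4 is 120 ug/mL, with an expected range from 35 ug/mL to 400 ug/mL.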

Compound 4, half-maximal inhibitory concentration: > 500 ug/mL
Compound 4: only a limit was reported (the forecaster's own chance of this, stated with the estimate: 20%); middle value at least 4.1-fold (0.61 log units) from the limit.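

In this assay compound 3 and compound 4 both sit at a limit and not at a number, so the step from methoxy to trifluoromethyl on this aromatic carbon cannot be read: the limit of > 500 ug/mL in this assay, at which 2 of the 4 values shown sit. The amine group does give a readable change: with trifluoromethyl kept, 3,5-dimethylpiperazin-1-yl in place of 3-(aminomethyl)pyrrolidin-1-yl gives an at least 13-fold higher number from compound 2 to compound 4 (1.11 log units; beyond the scatter), so a weaker inhibitor. Trifluoromethyl therefore does not bring a measurable number with every amine group.

From the compounds shown here alone, what a chlorine atom or a nitrile at this position would give in this assay stays open. So does whether methoxy paired with either pyrrolidine amine would fall below the limit.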